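The source may hold more compounds than are shown below. What is called first, only, known or untested is meant among the compounds shown, and "the series" means these compounds.

Measured compounds in a functional assay on MKN-45 cells (Homo sapiens) for cytotoxicity, read by MTT assay, with a stated time of 48 h; a lower number here means a stronger inhibitor, a higher number a weaker inhibitor:

Compound 1, `Cc1nnc(SCc2ccccc2)n1N1C(=O)c2ccccc2C1=O`: compound 1 gives > 200000 nM, a limit of the assay and not a number.
Compound 2, `CCOC(=O)CSc1nnc(CC)n1N1C(=O)c2ccccc2C1=O`: compound 2 gives > 200000 nM, likewise a limit.
Compound 3, `C#CCSc1nnc(-c2cc(OC)c(OC)c(OC)c2)n1N1C(=O)c2ccccc2C1=O`: compound 3 gives > 200000 nM, also a limit.

Compound 3 therefore stands where every value in the series stands, at the limit of > 200000 nM in this assay, at which 3 of the 3 values shown sit, so no ordering among compounds 1, 2 and 3 can be drawn. For the measured compounds named here, no step between measured compounds is available.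

Compound 4, `COc1cc(-c2nnc(SCc3ccccc3)n2N2C(=O)c3ccccc3C2=O)cc(OC)c1OC`, is not yet measured. It differs from compound 3 by phenyl in place of ethynyl on a saturated chain carbon bound to a sulfur. With nothing but limits to rest on, no shift beyond the scatter is expected in this assay; the expected step from compound 3 to compound 4 is a number no higher from compound 3 to compound 4 (the limit leaves the size open). Compound 4 is estimated at 200000 nM, in a range from 50000 nM to 500000 nM, most likely again reported only as a limit.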

Compound 4, half-maximal inhibitory concentration: > 200000 nM
Compound 4 ended at the assay's limit (the forecaster's own chance of this, stated with the estimate: 85%); the middle value lies on the limit itself.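

Compound 4, like compounds 1, 2 and 3, sits at a limit of the assay, so the steps to compound 4 from compound 3 and from compound 1 cannot be read. In this assay the compounds shown leave open which change, if any, would give a value inside the assay's range.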